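The source may hold more compounds than are shown below. What is called first, only, known or untested is meant among the compounds shown, and "the series" means these compounds.

Measured so far in an in vitro ADME assay on microsomes (Homo sapiens) for metabolic stability; on this read-out higher numbers stand for a longer-lived compound and lower numbers for a shorter-lived compound:

Compound 1 `CCc1nc(-c2ccc(Cl)cc2Cl)c(CC)nc1SC(C)CC` gives 0.283 h.
Compound 2 `CCc1nc(NC(CC)CC)c(OC)nc1-c1ccc(OC)cc1C(F)(F)F` gives 2 h.
Compound 3 `CCc1nc(NC(CC)CC)c(OC)nc1-c1ccc(Cl)cc1Cl` gives 0.583 h.

Compound 1 stands lowest of the three numbers in this assay. Its nearest neighbour is compound 3, whose number is higher by a margin beyond the usual scatter; the furthest is compound 2, whose number is higher still, also well beyond the scatter. Compounds 2 and 3 both carry an amino group on the shared core where compound 1 carries a sulfanyl group, and both sit above compound 1 in this assay.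

Compound 4 `CCc1nc(-c2ccc(Cl)cc2Cl)c(CC)nc1NC(C1CC1)C1CC1` is not yet measured. It differs from compound 1 in one place: (dicyclopropylmethyl)amino in place of (sec-butyl)sulfanyl on an aromatic carbon. Going by the values given here, no measured pair differs in exactly this way, so the size of the step cannot be read from a measured step; only the spread of the three numbers gives a guide.

On that basis the step from compound 1 to compound 4 in this assay is expected to be upward, of moderate size and beyond the scatter, a 2.5-fold higher number from compound 1 to compound 4 (0.39 log units; beyond the scatter). For compound 4 the expected value in this assay is 0.7 h, with a range from 0.3 h to 1.6 h.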

Compound 4, half-life: 0.183 h
Beside the measured number, compound 4's estimate is 3.8-fold (0.58 log units) above it, outside the stated range (below it).
By their numbers in this assay, from the lowest: compounds 4 and 1 (each within the scatter of the next); then compound 3; then compound 2.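

In this assay the exchange of (sec-butyl)sulfanyl for (dicyclopropylmethyl)amino on this aromatic carbon, next to the ring nitrogen, gives a 1.5-fold lower number from compound 1 to compound 4 (0.19 log units; within the scatter), so on the core of compound 1 these two groups cannot be told apart, even though the entering group brings a hydrogen-bond donor and two three-membered rings. Going by these compounds alone, this is the only measured step at this position, and it shows that an amino link here does not by itself go with a longer half-life: compound 2 and compound 3 carry an amino group too, but they differ from compound 1 in more than one place, so their numbers cannot be credited to that group alone. Nothing at hand gives a reason for this result.

Still open, as far as these compounds go, is whether the nitrogen link or the dicyclopropylmethyl part has the larger say in the number, a question that a (sec-butyl)amino or a (dicyclopropylmethyl)sulfanyl group on the core of compound 1 would separate. From the compounds shown here alone, how a cyclic amine such as morpholine would read at this place also remains open.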